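The source may hold more compounds than are shown below. What is called first, only, known or untested is meant among the compounds shown, and "the series" means these compounds.

Series in an assay on isolated protein for inhibition of steroid 5-alpha-reductase (Rattus norvegicus); a lower number here means a stronger inhibitor, a higher number a weaker inhibitor — measured compounds so far:

compound 1 `COc1ccccc1N1CCN(CCCOc2ccc(C(=O)Nc3ccccc3OCCCC(=O)O)cc2)CC1` — 41000 nM
compound 2 `COc1ccccc1N1CCN(CCCCOc2ccc(C(=O)Nc3ccccc3OCCCC(=O)O)cc2)CC1` — 43000 nM
compound 3 `COc1ccccc1N1CCN(CCC(Oc2ccc(NC(=O)c3ccccc3OCCCC(=O)O)cc2)c2ccccc2)CC1` — 730 nM

Compound 3 holds the lowest number of the three in this assay. Compound 1 and compound 2, which share the acid side chain and the aryl piperazine but carry a plain linker without the phenyl branch and with the amide turned the other way, both sit far higher, and the gap from compound 3 to either of them lies well beyond the scatter. Going by the values given here, no pair of measured compounds differs in only one place, so no single step has yet been quantified.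

Compound 4 `CCc1ccc(C(CCN2CCN(c3ccccc3OC)CC2)Oc2ccc(NC(=O)c3ccccc3OCCCC(=O)O)cc2)cc1` is the next candidate. Relative to compound 3 the change is ethyl in place of hydrogen on an aromatic carbon. Among the compounds with values here, nothing shows what such a change does in this assay; the only anchor is the value of compound 3. Within the data shown here, with no comparable step to lean on, the expected step from compound 3 to compound 4 is a 1.2-fold lower number from compound 3 to compound 4 (0.09 log units; within the scatter), that is, no change beyond the scatter in either direction, with the range kept wide to cover a moderate shift either way. For compound 4 the estimate in this assay is 600 nM, with a range from 200 nM to 2500 nM.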

Compound 4, half-maximal inhibitory concentration: 130 nM
The estimate for compound 4 lay 4.6-fold (0.66 log units) above the measured number; measured number below the stated range.
By their numbers in this assay, from the lowest: compound 4; then compound 3; then compounds 1 and 2 (each within the scatter of the next).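

In this assay, going by these compounds alone, the change from phenyl to 4-ethylphenyl gives a 5.6-fold lower number from compound 3 to compound 4 (0.75 log units; beyond the scatter), the first step that can be read at a single place. This aromatic carbon, para to a large group, therefore accepts ethyl, and the number falls rather than rises, so hydrogen at this carbon is not needed for the values seen so far; as a single step, this sets no trend for substituents here. No measured data bear on the origin of this step.

Open, as far as these compounds go, is whether methyl, a longer chain such as propyl or butyl, or a halogen such as chlorine on the same carbon would take the number further down, level off or reverse the step, so the size limit at this place remains unknown. Also open, from the compounds shown here alone, is how much of the gap to compound 1 and compound 2 belongs to the phenyl branch and how much to the turned amide or the linker, since those compounds differ from compound 3 in more than one place and the individual contributions cannot be read.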